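Swapping an amide for a sulfonamide on the shared core

A few compounds are considered here, and "the series" means these few. Any claim that something is new, unique, unknown or untested is made for them only; others in the source may bear on it.

Measured compounds in a functional assay on MCF7 cells (Homo sapiens) for antiproliferative activity, read by MTT assay, with a stated time of 48 h; a lower number here means a stronger inhibitor, a higher number a weaker inhibitor:
compound 1 `Cc1ccccc1C(=O)Nc1cccc(/C=C/C(=O)c2nc3ccccc3[nH]2)c1`, 5870 nM
compound 2 `Cc1ccc(C(=O)Nc2cccc(/C=C/C(=O)c3nc4ccccc4[nH]3)c2)cc1`, 9690 nM
compound 3 `COc1cccc(C(=O)Nc2cccc(/C=C/C(=O)c3nc4ccccc4[nH]3)c2)c1`, 17800 nM

Compound 3 stands highest of the three numbers. Its gap to compound 2 is within the scatter, while the step of a 3.0-fold higher number from compound 1 to compound 3 (0.48 log units; beyond the scatter) is modest but beyond it; the step of a 1.7-fold higher number from compound 1 to compound 2 (0.22 log units; within the scatter) and the step of a 1.8-fold higher number from compound 2 to compound 3 (0.26 log units; within the scatter) are both within the scatter.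

Compound 4 `O=C(/C=C/c1cccc(NS(=O)(=O)c2ccc(Cl)cc2)c1)c1nc2ccccc2[nH]1` differs from compound 3 in one place: (4-chlorophenyl)sulfonyl in place of (3-methoxyphenyl)carbonyl on a nitrogen on an aromatic ring. Among the compounds with values here, none of the measured steps bears directly on this change, since each of them only altered the aryl piece on a carbonyl carbon, leaving the carbonyl itself untouched. From the compounds shown here alone, those steps were at most modest, so no large move in this assay is foreseen, but the replacement of the whole carbonyl linker by a sulfonyl is untested here, and the estimate is accordingly wide. Compound 4 is expected to give about 12000 nM, within 3000 nM to 50000 nM, that is, an estimated step of a 1.5-fold lower number from compound 3 to compound 4 (0.17 log units; within the scatter).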

Compound 4, half-maximal inhibitory concentration: 3820 nM
Beside the measured number, compound 4's estimate is 3.1-fold (0.50 log units) above it, and the stated range covers the measured number.
By their numbers in this assay, from the lowest: compounds 4, 1, 2 and 3 (each within the scatter of the next, the first and the last beyond it).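

In this assay, within the data shown here, the linker on the nitrogen on an aromatic ring can change from a carbonyl to a sulfonyl without loss: the earlier compounds varied only the aryl piece on a carbonyl carbon, so this is the first sign that the carbonyl itself is not required. The sulfonyl compound with its 4-chlorophenyl gives modest gains over two of the amides (both beyond the scatter: a 4.7-fold lower number from compound 3 to compound 4 (0.67 log units; beyond the scatter) and a 2.5-fold lower number from compound 2 to compound 4 (0.40 log units; beyond the scatter)) and stays level with the 2-methylphenyl amide (a 1.5-fold lower number from compound 1 to compound 4 (0.19 log units; within the scatter)). No measurement is available to explain this shift.

From the compounds shown here alone, because the linker and the aryl piece changed together, their shares stay open, and 4-chlorophenyl on a carbonyl or 3-methoxyphenyl on a sulfonyl would separate them. Nor do the compounds shown tell what this assay would give for a methyl on the sulfonyl or a carboxylic acid on its aryl ring.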